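The source may hold more compounds than are shown below. What is called first, only, known or untested is meant among the compounds shown, and "the series" means these compounds.

Measured compounds in a functional assay on PC-3 cells (Homo sapiens) for inhibition; a lower number here means a stronger inhibitor, a higher number a weaker inhibitor:
Compound 1, `Cc1c(C(=O)N/N=C\c2cc(Cl)cc(Cl)c2O)oc2cccc(O)c12`: 9590 nM
Compound 2, `Cc1c(C(=O)N/N=C\c2ccccc2O)oc2cccc(O)c12`: 8350 nM
Compound 3, `Cc1c(C(=O)N/N=C\c2ccccc2C(F)(F)F)oc2cccc(O)c12`: 26200 nM

Compound 2 gives the lowest of the three numbers in this assay. Compound 1 lies within the scatter of it, so no order between compound 1 and compound 2 can be read from these values. Among the measured compounds shown here, compound 3 stands furthest away, and the step of a 3.1-fold higher number from compound 2 to compound 3 (0.50 log units; beyond the scatter) is the only measured step that bears on the question at hand.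

The unmeasured compound 4, `Cc1c(C(=O)N/N=C\c2ccco2)oc2cccc(O)c12`, differs from compound 2 in one place: furan-2-yl in place of 2-hydroxyphenyl on a carbon with a double bond to nitrogen. For the measured compounds named here, the one measured step that touches the same region of the molecule is a 3.1-fold higher number from compound 2 to compound 3 (0.50 log units; beyond the scatter), where the hydroxy on the aromatic ring was exchanged and the number rose modestly. Going by the values given here, compound 4 also gives up that hydroxy, so a rise of similar size, a weaker inhibitor than compound 2, is the expectation, though the smaller five-membered ring that enters has no direct precedent here.

Compound 4 is therefore estimated at 16000 nM in this assay, within a range of 6000 nM to 42000 nM. This estimate means an expected step of a 1.9-fold higher number from compound 2 to compound 4 (0.28 log units; within the scatter).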

Compound 4, half-maximal inhibitory concentration: >= 40000 nM
Compound 4: a limit, no number; the forecaster's own chance of this, stated with the estimate: 20%; at least 2.5-fold (0.39 log units) between middle value and limit.
By their numbers in this assay, from the lowest: compounds 2 and 1 (each within the scatter of the next); then compound 3. At a limit, above all of these: compound 4.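

In this assay compound 4 carries a limit of the assay and not a number, >= 40000 nM. Furan-2-yl in place of 2-hydroxyphenyl on the carbon with a double bond to nitrogen gives an at least 4.7-fold higher number from compound 2 to compound 4 (0.68 log units; beyond the scatter), which shows that this position can respond strongly to a change of the ring itself, whereas compounds 1, 2 and 3 all keep a six-membered aromatic ring of carbon only there. Compound 3 also lacks the hydroxy yet still gives a number, 26200 nM, so losing the hydroxy does not by itself leave a compound without a number.

Among the compounds shown here, how far compound 4 lies past that limit stays open, and only this compound sits there: the limit of >= 40000 nM in this assay, at which 1 of the 4 values shown sits. Also open is whether a thiophene ring or a 2-aminophenyl group at this place would give a number.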